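Trimming a Chloropyridyl Group and Plasma Protein Binding

This account rests on a few compounds, and the source may have more. Where it says the series, first, only, none or still open, it means among the compounds named here.

Compound 2 `C[C@@H](Oc1cc2oc(=O)n(CCC(=O)O)c2cc1Cl)c1ccc(Cl)cn1` is measured in an ADME assay on a cell-free system (plasma, Homo sapiens) for protein binding, at 99%, the lowest unbound fraction of the two values at hand. Its nearest neighbour is compound 1 `O=C(O)CCn1c(=O)oc2cc(OCc3ccccn3)c(Cl)cc21`, which in this assay gives 92.6%, a clearly higher unbound fraction, beyond the usual scatter. Compound 3 `CCOc1cc2oc(=O)n(CCC(=O)O)c2cc1Cl` is not yet measured; it differs from compound 2 by hydrogen in place of 5-chloropyridin-2-yl on a saturated chain carbon bound to an oxygen on an aromatic ring and a saturated chain carbon. With a large part of the molecule gone, a drop in binding beyond the scatter is expected, the estimated step from compound 2 being a 10-fold higher unbound fraction from compound 2 to compound 3 (1.00 log units; beyond the scatter). Compound 3 is therefore expected to show about 90%, within a range of 78% to 96%.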

Compound 3, plasma protein binding: 95.8%
Estimate against measurement, compound 3: 2.4-fold (0.38 log units) (unbound fraction) above; the measured number falls inside the stated range.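

In this assay hydrogen in place of 5-chloropyridin-2-yl on the saturated chain carbon gives a 4.2-fold higher unbound fraction from compound 2 to compound 3 (0.62 log units; beyond the scatter) and so shows that this group counts toward binding, although compound 3 remains largely bound. Methyl in place of pyridin-2-yl gives a 1.8-fold lower unbound fraction from compound 1 to compound 3 (0.25 log units; within the scatter) and so cannot be told apart from repeat variation. Nothing measured here explains either step. The compounds shown leave open what an amine or a longer chain in this place would do in this assay and how much the chlorine on the pyridine ring counts by itself.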